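The compounds below may be only part of what the source reports. "The series", "measured", "known", "first", "only" and "open" are said of these compounds alone.

In a functional assay on SK-BR-3 cells (Homo sapiens) for inhibition, read by sulforhodamine B assay, with a stated time of 48 h (a lower number here means a stronger inhibitor, a higher number a weaker inhibitor), compound 2 `CO[C@@H]1CC=C2NN(c3ccc(Cl)cc3)C(=O)C[C@]2(C)O1` gives 28700 nM, the highest of the three numbers recorded. Compound 1 `CO[C@@H]1CC=C2NN(c3cc(F)cc(Cl)c3)C(=O)C[C@]2(c2ccccc2)O1` gives 17600 nM in this assay, a number within the scatter of compound 2, while compound 3 `COc1cc(OC)cc(N2NC3=CC[C@@H](OC)O[C@@]3(C)CC2=O)c1` gives 5700 nM, a number lower than that of compound 2 by more than the scatter. Compound 4 `CO[C@@H]1CC=C2NN(c3cncnc3)C(=O)C[C@]2(C)O1` is not yet measured in this assay. It differs from compound 2 by one change: pyrimidin-5-yl in place of 4-chlorophenyl on an amide-type nitrogen in a ring. Going by the values given here, no step between measured compounds of this kind is available, so the expectation rests on compound 2 alone. A modest shift toward a higher number, possibly not beyond the scatter, is expected: a 1.6-fold higher number from compound 2 to compound 4 (0.20 log units; within the scatter). Compound 4 is therefore estimated at 45000 nM in this assay, with an expected range from 15000 nM to 150000 nM.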

Compound 4, half-maximal inhibitory concentration: 3400 nM
Estimate against measurement, compound 4: 13-fold (1.12 log units) above; the measured number lies below the stated range.
By their numbers in this assay, from the lowest: compounds 4 and 3 (each within the scatter of the next); then compounds 1 and 2 (each within the scatter of the next).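

In this assay, going by these compounds alone, the group on this amide-type nitrogen in a ring clearly matters: an 8.4-fold lower number from compound 2 to compound 4 (0.93 log units; beyond the scatter) follows when pyrimidin-5-yl takes the place of 4-chlorophenyl, a step beyond the scatter that no earlier pair could show. Within the data shown here, the entering ring brings hydrogen-bond acceptors and the leaving ring's chlorine is lost, but the single step cannot separate these differences. Nothing measured here explains the step. From the compounds shown here alone, whether a pyridin-3-yl ring or a plain phenyl ring would give a similar number remains open. So does whether the step would persist with another group in place of the methyl group.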